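The source may hold more compounds than are shown below. What is called first, only, known or untested is meant among the compounds shown, and "the series" means these compounds.

Measured in an ADME assay on microsomes from liver (Mus musculus) for metabolic stability, with a stated time of 10 min, tested at 0.5 uM; on this read-out higher numbers stand for a more stable compound and lower numbers for a less stable compound:

Compound 1 `C[C@@H](C(=O)NC1CCCCC1)[C@H]1CC[C@@H](c2ccnc3ccc(F)cc32)CC1`: < 1% (a limit of the assay)
Compound 2 `C[C@@H](CNc1ccc(Cl)cc1)[C@H]1CC[C@@H](c2ccnc3ccc(F)cc32)CC1`: 80%
Compound 3 `C[C@@H](NC(=O)c1ccccc1Cl)[C@H]1CC[C@@H](c2ccnc3ccc(F)cc32)CC1`: 7%

Compound 3 gives 7%. Compound 2 gives 80%. Compound 3 stands lower than compound 2, and the gap between the two lies well beyond the scatter. Compound 4 `C[C@@H](NC(=O)C1CCCCC1)[C@H]1CC[C@@H](c2ccnc3ccc(F)cc32)CC1` carries cyclohexyl in place of 2-chlorophenyl on a carbonyl carbon. For the measured compounds named here, the only measured step, a number at least 79 percentage points higher from compound 1 to compound 2 (beyond the scatter), is large, but it changes a different group and bears only indirectly. Compound 1, which also contains cyclohexyl, reads < 1%, and that reading is a limit. No step beyond the scatter is therefore expected in this assay, and the estimated change is a number 4 percentage points lower from compound 3 to compound 4 (within the scatter). For compound 4 the estimated value is 3%, with an expected range from 0.5% to 12%.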

Compound 4, percent of the compound remaining: 5%
Compound 4: middle estimate off by 2 percentage points, on the low side, within the range that was stated.
By their numbers in this assay, from the lowest: compounds 4 and 3 (each within the scatter of the next); then compound 2. At a limit, below all of these: compound 1.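

In this assay cyclohexyl in place of 2-chlorophenyl on a carbonyl carbon gives a number 2 percentage points lower from compound 3 to compound 4 (within the scatter) and so shows that, at this position, this swap of rings moves the number by no more than the scatter. The large gap lies instead in the exchange of ((4-chlorophenyl)amino)methyl for (cyclohexylcarbonyl)amino (a number 75 percentage points lower from compound 2 to compound 4 (beyond the scatter)). The comparison with compound 1 (a number at least 4 percentage points higher from compound 1 to compound 4 (that floor lies within the scatter)) rests on a limit of the assay: the limit of < 1% in this assay, at which 1 of the 4 values shown sits.

Open remains how a piperidine or a carboxylic acid on that carbonyl carbon would read in this assay and whether either would leave the number unchanged.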